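Swapping Trifluoromethoxy for tert-Butyl on a Shared Sulfonamide Core

This account rests on a few compounds, and the source may have more. Where it says the series, first, only, none or still open, it means among the compounds named here.

Of the compounds shown here, three built on one shared core have been tested in a functional assay on CHO cells for inhibition of Orexin/Hypocretin receptor type 1 (Homo sapiens), read by FLIPR and calcium flux; on this read-out higher numbers stand for weaker inhibition and lower numbers for stronger inhibition. Compound 1 `CCN(CC)C(=O)CN(c1ccc(C)cc1)S(=O)(=O)c1ccc(OC)c(OC)c1` gives > 10000 nM in this assay, which is a limit of the assay rather than a measured number. Compound 2 `CCN(CC)C(=O)CN(c1ccc(C)cc1)S(=O)(=O)c1ccc(OC(F)(F)F)cc1` likewise gives > 10000 nM in this assay, again a limit. Compound 3 `CCN(CC)C(=O)CN(c1ccc(C)cc1)S(=O)(=O)c1cccc(C)c1` gives > 10000 nM in this assay, also a limit. Compound 2 therefore stands exactly where the whole set stands, at the limit of > 10000 nM in this assay, at which 3 of the 3 values shown sit.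

Compound 4 `CCN(CC)C(=O)CN(c1ccc(C)cc1)S(=O)(=O)c1ccc(C(C)(C)C)cc1` differs from compound 2 in a single place: tert-butyl in place of trifluoromethoxy on an aromatic carbon. Among the compounds with values here, no two measured compounds differ from each other in only one spot, so the measured set offers no step from which the effect of changing a group on this ring could be read. With every measured value resting at a limit, the step from compound 2 to compound 4 is expected to be none beyond the usual scatter, estimated as a step that the limit leaves unreadable from compound 2 to compound 4. Compound 4 is thus expected to give about 15000 nM in this assay, with an estimated range from 4000 nM to 60000 nM, and most likely to be reported again only as a limit.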

Compound 4, half-maximal inhibitory concentration: > 10000 nM
Compound 4 was reported as a limit; the forecaster's own chance of this, stated with the estimate: 80%; the middle value lies beyond the limit too.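

No step can be read between compound 2 and compound 4, since both rest at a limit, so the effect of tert-butyl in place of trifluoromethoxy stays unknown: the limit of > 10000 nM in this assay, at which 4 of the 4 values shown sit.

The compounds shown leave open which change to the shared core, if any, would bring a measurable value in this assay.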